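The compounds below may be only part of what the source reports. "The series", "measured", "known", "first", "only" and "open" are said of these compounds alone.

Compound 1 `C=C1CC[C@H]2[C@@](C)(CC[C@@H](OC(C)=O)[C@@]2(C)C(=O)OCc2ccccc2)[C@@H]1CCC1=CCOC1=O` gives 12900 nM
Compound 2 `C=C1CC[C@H]2[C@@](C)(CC[C@@H](OC(C)=O)[C@@]2(C)C(=O)OCc2ccccn2)[C@@H]1CCC1=CCOC1=O` gives 55500 nM
Compound 3 `C=C1CC[C@H]2[C@@](C)(CC[C@@H](O)[C@@]2(C)C(=O)OCc2ccccc2)[C@@H]1CCC1=CCOC1=O` gives 37900 nM

In a functional assay on NIH3T3 cells (Mus musculus) for inhibition, read by MTT assay, with a stated time of 72 h (a lower number here means a stronger inhibitor, a higher number a weaker inhibitor), compound 1 stands lowest of these three numbers. Compound 4 `C=C1CC[C@H]2[C@@](C)(CC[C@@H](OC(C)=O)[C@@]2(C)C(=O)OCc2ccccc2)[C@@H]1/C=C/C1=CCOC1=O` differs from it in one group: a group of 8 heavy atoms (6 carbon, 2 oxygen; one five-membered non-aromatic ring with 1 hetero atom) in place of a group of 8 heavy atoms (6 carbon, 2 oxygen; one five-membered non-aromatic ring with 1 hetero atom), on a saturated ring carbon, on a saturated ring carbon of a six-membered non-aromatic ring of carbon only. Neither measured step touches that group. Both a 4.3-fold higher number from compound 1 to compound 2 (0.63 log units; beyond the scatter) and a 2.9-fold higher number from compound 1 to compound 3 (0.47 log units; beyond the scatter) were modest, but they come from changes elsewhere and show only how far single changes have moved these compounds. A step no larger than those is expected in this assay, leaning to a higher number and estimated as a 1.6-fold higher number from compound 1 to compound 4 (0.19 log units; within the scatter). For compound 4 the estimated value is 20000 nM, with an expected range from 6000 nM to 60000 nM.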

Compound 4, half-maximal inhibitory concentration: 52700 nM
Compound 4: the middle estimate sits 2.6-fold (0.42 log units) below what was measured; measured number inside the range.
By their numbers in this assay, from the lowest: compound 1; then compounds 3, 4 and 2 (each within the scatter of the next).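

Compound 4 shows that the group on this saturated ring carbon also matters in this assay: with the same number and kind of heavy atoms, but 3 double bonds outside aromatic rings instead of 2, the change gives a 4.1-fold higher number from compound 1 to compound 4 (0.61 log units; beyond the scatter). The number rises here as it did at the two other places changed, and compound 1 remains the lowest of the four. Nothing measured here accounts for this step. From the compounds shown here alone, whether the step would hold alongside the pyridin-2-yl group of compound 2 or the free hydroxyl of compound 3 remains open, as does the effect of a longer chain or an amine at this position.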